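From methylamino to ethylamino on a shared core

The compounds below may be only part of what the source reports. "The series", "measured", "known", "first", "only" and "open" are said of these compounds alone.

In an ADME assay on GM00637 cells (Homo sapiens) for cytotoxicity, read by MTT assay, with a stated time of 72 h (on this read-out higher numbers stand for weaker inhibition and lower numbers for stronger inhibition), compound 1 (`O=c1ccc2nc(-c3ccccc3)nn(-c3ccccc3)c-2c1`) gives 230 nM and compound 2 (`CNc1cc2nc(-c3ccccc3)nn(-c3ccccc3)c-2cc1=O`) gives 930 nM as the higher of the two numbers. Compound 3 (`CCNc1cc2nc(-c3ccccc3)nn(-c3ccccc3)c-2cc1=O`) differs from compound 2 by one change (methyl in place of hydrogen on a saturated chain carbon bound to a nitrogen on an aromatic ring), which is methyl in place of hydrogen on a saturated chain carbon bound to a nitrogen on an aromatic ring, turning methylamino into ethylamino. For the measured compounds named here, no measured step shows this exact change. The nearest guide is the modest step beyond the scatter (a 4.0-fold higher number from compound 1 to compound 2 (0.61 log units; beyond the scatter)), which brought in the methylamino group itself and is a larger change than the one here. In this assay the expected step is therefore small, within the scatter and if anything towards a higher number (a 1.2-fold higher number from compound 2 to compound 3 (0.07 log units; within the scatter)). The estimated value for compound 3 is 1100 nM with an expected range (450 nM to 2600 nM).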

Compound 3, half-maximal inhibitory concentration: 240 nM
For compound 3 the middle estimate is 4.6-fold (0.66 log units) above the measured one; measured number below the stated range.
By their numbers in this assay, from the lowest: compounds 1 and 3 (each within the scatter of the next); then compound 2.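

In this assay the amino substituent on this aromatic carbon carries no fixed penalty: adding one methyl to the saturated chain carbon gives a 3.9-fold lower number from compound 2 to compound 3 (0.59 log units; beyond the scatter) and so runs opposite to the step that brought in methylamino. Measured against the hydrogen of compound 1, ethylamino gives a 1.0-fold higher number from compound 1 to compound 3 (0.02 log units; within the scatter) and cannot be told apart from it on this read-out, which leaves methylamino in compound 2 as the only group shown here that stands apart from hydrogen at this place. Nothing available here bears on what lies behind this reversal.

With only hydrogen, methylamino and ethylamino shown, the compounds leave open whether a longer chain such as propylamino would stay level with ethylamino or move away from it. They also leave open what a second group on the nitrogen, as in dimethylamino, would do to the number.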